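Carbonyl substituent change in the chloropyridine piperazine series

The compounds below may be only part of what the source reports. "The series", "measured", "known", "first", "only" and "open" are said of these compounds alone.

Measured in a functional assay for antagonist activity at C-X-C chemokine receptor type 3 (Homo sapiens); a lower number here means a stronger inhibitor, a higher number a weaker inhibitor:
Compound 1 `CNC(=O)c1cnc(N2CCN(C3CCN(Cc4ccco4)CC3)[C@@H](C)C2)c(Cl)c1` gives 8100 nM.
Compound 2 `CNC(=O)c1cnc(N2CCN(C3CCN(Cc4ccc(F)cc4Cl)CC3)[C@@H](C)C2)c(Cl)c1` gives 58 nM.
Compound 3 `CC(=O)c1cnc(N2CCN(C3CCN(Cc4ccc(Cl)cc4)CC3)[C@@H](C)C2)c(Cl)c1` gives 520 nM.

Compound 3 stands second highest of the three numbers. Its nearest neighbour is compound 2, whose number is lower by a step beyond the scatter; its furthest is compound 1, whose number is higher, also beyond the scatter. Compound 2 and compound 3 differ in two places at once, so their gap cannot be assigned to either change.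

Compound 4 `C[C@H]1CN(c2ncc(C(=O)N3CCCCC3)cc2Cl)CCN1C1CCN(Cc2ccc(Cl)cc2)CC1` is not yet measured. It differs from compound 3 as follows: piperidin-1-yl in place of methyl on a carbonyl carbon

For the measured compounds named here, the only measured single-place step, a 140-fold lower number from compound 1 to compound 2 (2.15 log units; beyond the scatter), concerns the group on the saturated chain carbon bound to the ring amine nitrogen, not the carbonyl carbon, so it does not bear on this change. Going by the values given here, no measured pair isolates a change at the carbonyl carbon. Compounds 1 and 2 carry a methylamino group on that carbonyl and compound 3 an acetyl, but the accompanying benzyl change confounds any reading.

Among the compounds with values here, with no direct precedent, a step of modest size in either direction is expected for compound 4, a 1.3-fold lower number from compound 3 to compound 4 (0.11 log units; within the scatter), with wide uncertainty. Compound 4 is estimated at 400 nM, between 100 nM and 2000 nM.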

Compound 4, half-maximal inhibitory concentration: 900 nM
For compound 4 the middle estimate is 2.3-fold (0.35 log units) below the measured one; the measured number falls inside the stated range.
By their numbers in this assay, from the lowest: compound 2; then compounds 3 and 4 (each within the scatter of the next); then compound 1.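

In this assay, for the compounds shown here, the first step that isolates the carbonyl carbon is a 1.7-fold higher number from compound 3 to compound 4 (0.24 log units; within the scatter), so acetyl and (piperidin-1-yl)carbonyl cannot be told apart at this position. On a carbonyl carbon whose other neighbour is an aromatic carbon, the single heavy atom of methyl can therefore give way to the 6 heavy atoms and six-membered non-aromatic ring of piperidin-1-yl with no separation in this assay, a reading that rests on this one pair alone. Nothing measured here bears on why the two compounds read alike.

The methylamino group carried on the carbonyl by compounds 1 and 2 remains unconnected to this pair, as neither compound shares the benzyl group of compound 3 or compound 4, so its standing against acetyl or piperidin-1-yl cannot be read. Also open, going by these compounds, is whether a morpholin-4-yl group, a dimethylamino group or a carboxylic acid at the same carbonyl position would stay level with compound 3 or move the number beyond the scatter.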